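A few compounds are considered here, and "the series" means these few. Any claim that something is new, unique, unknown or untested is made for them only; others in the source may bear on it.

Measured so far:
compound 1 `CCCCn1ccc(N2CCN(c3nc(C)cc(C)n3)CC2)c(C#N)c1=O` — 631 nM
compound 2 `Cc1cc(C)nc(N2CCN(c3ccn4c(CC(F)(F)F)cnc4c3C#N)CC2)n1` — 447 nM
compound 3 `CCCc1cnc2c(C#N)c(N3CCN(c4ncccn4)CC3)ccn12` — > 3160 nM (a limit)

In a functional assay on CHO cells with metabotropic glutamate receptor 2 (Homo sapiens) as the target, read by GTPgammaS binding (a lower number here means that less compound is needed, a higher number that more compound is needed for the effect), compound 2 gives 447 nM, and compound 1 gives 631 nM; the two numbers lie within the scatter of each other, so neither can be called the stronger. In this assay compound 3 returns only a limit, > 3160 nM; (the limit of > 3160 nM in this assay, at which 1 of the 3 values shown sits).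

Compound 4 `CCCc1cnc2c(C#N)c(N3CCN(c4nc(C)cc(C)n4)CC3)ccn12` is not yet measured. It differs from compound 2 by ethyl in place of trifluoromethyl on a saturated chain carbon bound to an aromatic carbon. Going by the values given here, no measured pair shows this change alone; compound 3 carries the same propyl chain but also differs elsewhere and stands at a limit, so its number gives no size for the chain change. A step of a 2.2-fold higher number from compound 2 to compound 4 (0.35 log units; beyond the scatter) is expected, toward more compound needed. Compound 4 is therefore estimated at 1000 nM, between 400 nM and 3000 nM.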

Compound 4, half-maximal effective concentration: 646 nM
Beside the measured number, compound 4's estimate is 1.5-fold (0.19 log units) above it, within the range that was stated.
By their numbers in this assay, from the lowest: compounds 2, 1 and 4 (each within the scatter of the next). At a limit, above all of these: compound 3.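

In this assay, going by these compounds alone, 2,2,2-trifluoroethyl to propyl is the first single change read at this place: a 1.4-fold higher number from compound 2 to compound 4 (0.16 log units; within the scatter), so these two chains cannot be told apart here. The change to 4,6-dimethylpyrimidin-2-yl from pyrimidin-2-yl on an amine nitrogen in a ring gives an at least 4.8-fold lower number from compound 3 to compound 4 (0.68 log units; beyond the scatter). That step has only a lower bound, as compound 3 stands at a limit: the limit of > 3160 nM in this assay, at which 1 of the 4 values shown sits.

From the compounds shown here alone, how a longer chain such as hexyl, or a chain ending in a carboxylic acid, would read at this place remains open. Going by these compounds, the full size of the step from compound 3 also remains open.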